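Toward compound 4 in a cytotoxicity series that sits at its limit

The compounds below may be only part of what the source reports. "The series", "measured", "known", "first", "only" and "open" are said of these compounds alone.

Compound 1 `CC(C)N(Cc1cccc(OCCCCCC(=O)O)c1)C(=O)c1ccc(-c2ccncc2)cc1`, in an ADME assay on HepG2 cells (Homo sapiens) for cytotoxicity, read by CellTiter-Glo and resazurin assay, with a stated time of 72 h; on this read-out higher numbers stand for an effect only at larger amounts of compound and lower numbers for an effect already at smaller amounts: > 26000 nM, a limit of the assay.
Compound 2 `CC(C)N(Cc1cccc(OCCCCCC(=O)O)c1)C(=O)c1ccc(-c2cccc(Br)c2)cc1`: > 26000 nM, a limit.
Compound 3 `CCOC(=O)CCCCCOc1cccc(CN(C(=O)c2ccc(-c3ccncc3)cc2)C(C)C)c1`: > 26000 nM, a limit.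

Compound 3 stands at the limit of > 26000 nM in this assay, at which 3 of the 3 values shown sit, so no number for it is known. Compound 4 `CCOC(=O)CCCCCOc1cccc(CN(C(=O)c2ccc(-c3cccc(OC(C)C)c3)cc2)C(C)C)c1` departs from it by one change: 3-isopropoxyphenyl in place of pyridin-4-yl on an aromatic carbon. The two measured steps, a step that the two limits leave unreadable from compound 1 to compound 2 and a step that the two limits leave unreadable from compound 1 to compound 3, both run between limits and give no readable size, so nothing about this swap can be drawn from them. Among the measured compounds shown here, with no step of readable size anywhere in the set, compound 4 is expected to fall at 30000 nM, within 10000 nM to 100000 nM, most probably reported again only as a limit. The expected step is accordingly a step that the limit leaves unreadable from compound 3 to compound 4.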

Compound 4, half-maximal effective concentration: > 26000 nM
Compound 4 was reported as a limit (the forecaster's own chance of this, stated with the estimate: 70%); the middle value lies beyond the limit too.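

Among the compounds shown here, compound 3 and compound 4 are both reported only as a limit, so no step between them can be read: the limit of > 26000 nM in this assay, at which 4 of the 4 values shown sit. The compounds shown leave open at what concentration any of them would affect the cells.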